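Chloro for Methyl on Two Related Thiazolopyrimidinone Cores

The source may hold more compounds than are shown below. What is called first, only, known or untested is meant among the compounds shown, and "the series" means these compounds.

This account concerns three measured compounds and one unmeasured compound, all examined in an assay on CHO cells for displacement of a labelled ligand from adenosine receptor A1 (Homo sapiens), read by scintillation counting, with a stated time of 120 min, tested at 1 uM; a higher number here means more inhibition at the concentration tested (going by the name of the read-out), a lower number less inhibition. Compound 1, `Cc1cccc(-c2nc3c(=O)[nH]c(C)nc3s2)c1`, gives 1%. Compound 2, `Cc1nc2sc(-c3cccc(Cl)c3)nc2c(=O)[nH]1`, gives 24%. Among the compounds with values here, the two differ in one place only, (chloro in place of methyl on an aromatic carbon), and the step of a number 23 percentage points higher from compound 1 to compound 2 (beyond the scatter) is the only counted step among the measured compounds.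

Compound 3, `Cc1ccc(Nc2nc3c(=O)[nH]c(C)nc3s2)cc1`, gives 20%. The values of compound 3 and compound 2 lie within the usual scatter of each other, so no order between them is claimed. Compound 3 and compound 1 differ by more than a single change, and the difference between the two cores is not broken down here; their values alone show compound 3 higher than compound 1, beyond the scatter.

Compound 4, `Cc1nc2sc(Nc3ccc(Cl)cc3)nc2c(=O)[nH]1`, has not yet been measured. It differs from compound 3 by chloro in place of methyl on an aromatic carbon. Within the data shown here, this is the same kind of change as the one from compound 1 to compound 2, but not the same: there the chloro sits meta to a large group, here para to a large group. Resting on the step of a number 23 percentage points higher from compound 1 to compound 2 (beyond the scatter) observed for that kind of change, and on the value of compound 3, 20%, the step from compound 3 to compound 4 is expected to be a number 10 percentage points higher from compound 3 to compound 4 (within the scatter). The estimate for compound 4 in this assay is 30%, expected to fall between 10% and 55%.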

Compound 4, a percentage reported as inhibition, at one concentration (the size of the read-out at that concentration, not a potency): 33%
The estimate for compound 4 lay 3 percentage points below the measured number; the measured number falls inside the stated range.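

In this assay, chloro in place of methyl on an aromatic carbon gives a number 13 percentage points higher from compound 3 to compound 4 (beyond the scatter), so the change goes in the same direction on the core of compound 3 as it did on the core of compound 1. Set side by side, the two steps cannot be told apart in size: the same change on two cores in this assay, a number 23 percentage points higher (beyond the scatter) from compound 1 to compound 2 and a number 13 percentage points higher (beyond the scatter) from compound 3 to compound 4, 10 percentage points apart, within the scatter of two such steps. Within the data shown here, this shows that, in these two matched pairs, the gain from the change carried over from one core to the other, but it rests on only two pairs, each read at a single concentration, and the chloro does not sit in the same place in both, being para to a large group in compound 4 only, so it establishes no general rule for the series and does not separate the effect of the core from that of the position.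

The compounds shown leave open whether a group other than chloro at this place, such as fluoro, methoxy or a nitrile, would move the number in the same way. They also leave open whether the same change would hold if the methyl kept on the shared ring system gave way to a longer chain or an amine.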